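Bromo to piperidin-1-yl on the 4-aminocyclohexyl series

This account rests on a few compounds, and the source may have more. Where it says the series, first, only, none or still open, it means among the compounds named here.

In a functional assay on HCT-116 cells (Homo sapiens) for cytotoxicity, read by MTT assay, with a stated time of 72 h (a lower number here means a stronger inhibitor, a higher number a weaker inhibitor), the measured compounds read as follows:
- Compound 1 `N[C@H]1CC[C@H](Nc2c(C(=O)NCc3ccc(F)cc3)nc(N3CCCCS3(=O)=O)c3cccnc23)CC1` gives > 10000 nM (a limit of the assay)
- Compound 2 `NCCCNc1c(C(=O)NCc2ccc(F)cc2)nc(Br)c2cccnc12` gives 18000 nM
- Compound 3 `N[C@H]1CC[C@H](Nc2c(C(=O)NCc3ccc(F)cc3)nc(Br)c3cccnc23)CC1` gives 4000 nM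

Compound 3 has the lowest number among the compounds with a measured value, and compound 2 lies beyond the scatter from it (a 4.5-fold lower number from compound 2 to compound 3 (0.65 log units; beyond the scatter)). Compound 4 `N[C@H]1CC[C@H](Nc2c(C(=O)NCc3ccc(F)cc3)nc(N3CCCCC3)c3cccnc23)CC1` keeps the 4-aminocyclohexyl group of compound 3 and carries piperidin-1-yl in place of bromo on an aromatic carbon. The step at this same carbon is the closest guide (an at least 2.5-fold lower number from compound 1 to compound 3 (0.39 log units; beyond the scatter)), and there bromine replaces a six-membered non-aromatic ring. The other step (a 4.5-fold lower number from compound 2 to compound 3 (0.65 log units; beyond the scatter)) concerns the amine side chain and does not touch this carbon. Piperidin-1-yl is also a six-membered non-aromatic ring, so a modest rise in this assay is expected, and a result reported only as a limit is possible. The expected change is modest (a 1.8-fold higher number from compound 3 to compound 4 (0.24 log units; within the scatter)). Compound 4 is estimated at 7000 nM (expected range 2000 nM to 25000 nM).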

Compound 4, half-maximal inhibitory concentration: 8500 nM
Estimate against measurement, compound 4: 1.2-fold (0.08 log units) below; the range from low to high includes it.
By their numbers in this assay, from the lowest: compound 3; then compound 4; then compound 2.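

In this assay, piperidin-1-yl in place of bromo on the aromatic carbon next to the ring nitrogen gives a 2.1-fold higher number from compound 3 to compound 4 (0.33 log units; beyond the scatter) and so a modest step towards a weaker inhibitor. This carbon therefore accepts piperidin-1-yl with a measurable value, but the change does not improve on the bromo of compound 3. The step of an at least 1.1-fold lower number from compound 1 to compound 4 (0.07 log units; that floor lies within the scatter) gives only a floor, and no order of the two compounds can be read from it. Compound 1 stands at a limit of the assay, not at a number: the limit of > 10000 nM in this assay, at which 1 of the 4 values shown sits.

The compounds shown do not tell how morpholine, dimethylamino or chlorine would read at this carbon. As far as these compounds go, it also remains open whether the step from bromo to piperidin-1-yl holds with 3-aminopropyl on the amine side chain, which appears here only with bromo, in compound 2.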